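A few compounds are considered here, and "the series" means these few. Any claim that something is new, unique, unknown or untested is made for them only; others in the source may bear on it.

Three compounds have numbers in an ADME assay on CCRF-CEM cells (Homo sapiens) for antiproliferative activity, with a stated time of 48 h (on this read-out lower numbers stand for stronger inhibition and higher numbers for weaker inhibition), so far: compound 1 (`C=C(Br)C(=O)Nc1ccc(C(=O)/C=C/c2cccc(OC)c2)cc1`) gives 1800 nM against compound 2 (`C=C(Br)C(=O)Nc1ccc(C(=O)/C=C/c2ccccc2OC)cc1`) at 580 nM and compound 3 (`C=C(Br)C(=O)Nc1ccc(C(=O)/C=C/c2cccc(OC)c2OC)cc1`) at 710 nM on this read-out. Compound 3 lies within the scatter of compound 2 and under compound 1 by more than the scatter. Compound 4 (`C=C(Br)C(=O)Nc1ccc(C(=O)/C=C/c2ccc(OC)c(OC)c2OC)cc1`) differs from compound 3 by one change (methoxy in place of hydrogen on an aromatic carbon): methoxy in place of hydrogen on an aromatic carbon, ortho to a methoxy group, meta to a methoxy group and para to a large group. Two measured steps add a methoxy elsewhere on the aromatic ring. One is a 2.5-fold lower number from compound 1 to compound 3 (0.40 log units; beyond the scatter) and is modest, the other is a 1.2-fold higher number from compound 2 to compound 3 (0.09 log units; within the scatter) and is the closer precedent, as its ring already holds a methoxy. The step of a 3.1-fold lower number from compound 1 to compound 2 (0.49 log units; beyond the scatter) only moves a methoxy. Within the data shown here, no measured compound has a methoxy para to a large group, so the precedent is incomplete. The expected size is a 1.0-fold lower number from compound 3 to compound 4 (0.02 log units; within the scatter) with no shift beyond the scatter expected in this assay and no direction favoured. Compound 4 is estimated at 680 nM with an expected range from 280 nM to 1600 nM in this series.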

Compound 4, half-maximal inhibitory concentration: 840 nM
For compound 4 the middle estimate is 1.2-fold (0.09 log units) below the measured one; the measured number falls inside the stated range.
By their numbers in this assay, from the lowest: compounds 2, 3 and 4 (each within the scatter of the next); then compound 1.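

In this assay, methoxy in place of hydrogen on the aromatic carbon ortho to a methoxy group, meta to a methoxy group and para to a large group gives a 1.2-fold higher number from compound 3 to compound 4 (0.07 log units; within the scatter). Compound 4 is the first compound shown with a methoxy para to a large group, so this position now has a direct reading: the added group brings no shift beyond the scatter. The step of a 1.2-fold higher number from compound 2 to compound 3 (0.09 log units; within the scatter) reads the same way, while a 2.5-fold lower number from compound 1 to compound 3 (0.40 log units; beyond the scatter) goes against treating every added methoxy on this ring as neutral.

Open, on these data alone, is whether an amine, a carboxylic acid or a longer alkoxy chain at this position would also stay within the scatter of compound 3. No supporting data bear on what lies behind this flat step.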